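The source may report more compounds than this note shows. Statements on the series, on what has been measured and on what is new or still open speak of the compounds shown alone.

Compound 1 `c1ccc(-c2nnc(Nc3ncccn3)o2)cc1` and compound 2 `COc1cc(-c2nnc(Nc3ncccn3)o2)cc(OC)c1OC` share the same core and were both tested in a functional assay, with a stated time of 30 min, tested at 20 uM; on this read-out lower numbers stand for less inhibition and higher numbers for more inhibition at the one concentration tested (going by the name of the read-out). In this assay compound 1 gives 51.4% and compound 2 gives 57.7%; compound 1 holds the lower of the two numbers, yet the gap between them lies within the usual scatter, so the two cannot be told apart. Compound 3 `Clc1ccc(-c2nnc(Nc3ncccn3)o2)cc1` has not yet been measured; it differs from compound 1 by chloro in place of hydrogen on an aromatic carbon. For the measured compounds named here, no measured step of this kind exists here, so the step is expected to stay within the scatter, a number 3.6 percentage points higher from compound 1 to compound 3 (within the scatter). Compound 3 is estimated at 55%, between 38% and 72%.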

Compound 3, a percentage reported as inhibition, at one concentration (the size of the read-out at that concentration, not a potency): 46.2%
Estimate against measurement, compound 3: 8.8 percentage points above, within the range that was stated.
By their numbers in this assay, from the lowest: compounds 3, 1 and 2 (each within the scatter of the next, the first and the last beyond it).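

In this assay chloro in place of hydrogen on the aromatic carbon para to a large group gives a number 5.2 percentage points lower from compound 1 to compound 3 (within the scatter) and so cannot be told apart from the hydrogen of compound 1. This position therefore accepts a single chlorine with no clear change in inhibition at the one concentration tested, although a small real change cannot be ruled out. Nothing available accounts for this result.

Going by these compounds, whether an amine or a carboxylic acid at this position would move the number beyond the scatter remains open. Potency also remains open, since one concentration gives no measure of it.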